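The source may report more compounds than this note shows. Statements on the series, on what has been measured and on what is new or still open speak of the compounds shown alone.

Working notes on the series. Compound 1 `O=C(Cn1c(=O)oc2cc([N+](=O)[O-])ccc21)Nc1ccccc1` gives 18% in an ADME assay on RAW264.7 cells (Mus musculus) for cytotoxicity, read by MTT assay, with a stated time of 72 h, tested at 50 uM; a higher number here means a stronger effect of the compound at the concentration tested, a lower number a weaker effect. Compound 2 `O=C(Cn1c(=O)oc2ccccc21)NCc1cccs1` gives 23.4% in this assay. Compound 3 `O=C(Cn1c(=O)oc2cc([N+](=O)[O-])ccc21)NCc1ccco1` gives 26.8% in this assay. Among the compounds with values here, the number for compound 3 is the largest of the three, but neither gap is more than the usual scatter: compound 2 is nearest and compound 1 furthest, and the one counted step, a number 8.8 percentage points higher from compound 1 to compound 3 (within the scatter), stays within the scatter as well.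

Compound 4 `O=C(Cn1c(=O)oc2cc([N+](=O)[O-])ccc21)NCc1cccs1` has not been measured in this assay. It differs from compound 3 in one place: thiophen-2-yl in place of furan-2-yl on a saturated chain carbon bound to an amide-type nitrogen. Within the data shown here, no measured step covers this exchange. Compound 2 carries the same thiophen-2-yl methyl group but lacks the nitro group of compound 3, so only its value can be set beside that of compound 3, and the two lie within the scatter of each other. All three numbers sit in a narrow band, so for compound 4 no step beyond the scatter is expected, a number 1.8 percentage points lower from compound 3 to compound 4 (within the scatter). The estimate for compound 4 is 25%, expected to fall between 14% and 36%.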

Compound 4, a percentage reported as inhibition, at one concentration (the size of the read-out at that concentration, not a potency): 36.6%
The estimate for compound 4 lay 11.6 percentage points below the measured number, and the stated range ends below it.
By their numbers in this assay, from the lowest: compounds 1, 2, 3 and 4 (each within the scatter of the next, the first and the last beyond it).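

In this assay, thiophen-2-yl in place of furan-2-yl on a saturated chain carbon bound to an amide-type nitrogen gives a number 9.8 percentage points higher from compound 3 to compound 4 (within the scatter), so this exchange alone stays unresolved. Within the data shown here, with (thiophen-2-yl)methyl held constant, nitro in place of hydrogen on an aromatic carbon gives a number 13.2 percentage points higher from compound 2 to compound 4 (beyond the scatter), and with the nitro group held constant, changing the group on the amide-type nitrogen gives a number 18.6 percentage points higher from compound 1 to compound 4 (beyond the scatter); these are the series' only steps that clear the scatter, whereas the earlier compounds gave none. No available evidence bears on the origin of these steps.

Going by these compounds, whether the nitro step also holds with (furan-2-yl)methyl on the amide nitrogen remains open. So does the effect of an amine in place of nitro, or of a longer chain carrying the thiophen-2-yl group.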